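The compounds below may be only part of what the source reports. "The series", "measured", "known", "first", "only" and "open" are said of these compounds alone.

Measured so far:
- compound 1 `CCCCOc1cc(OC)c(Br)cc1C(C)=O`: 42300000 nM
- compound 2 `CCCCCCOc1cc(OC)c(Br)cc1C(C)=O`: 42400000 nM
- compound 3 `CCCCCCCCOc1cc(OC)c(Br)cc1C(C)=O`: 39000000 nM

Not yet measured:
- compound 4 `CCCCCCCCCCOc1cc(OC)c(Br)cc1C(C)=O`

These compounds share one core and differ only in the length of the saturated chain attached through an oxygen on an aromatic ring. In a functional assay, with a stated time of 30 min (on this read-out lower numbers stand for stronger inhibition and higher numbers for weaker inhibition), compound 3 gives 39000000 nM, which is level with compound 1 and compound 2 within the scatter of the measurement.

Going on to compound 4 extends the chain once more: ethyl in place of hydrogen on a saturated chain carbon, eight bonds along the chain from an oxygen on an aromatic ring. The closest guide is the same ethyl swap made six bonds along the chain, which gave a 1.1-fold lower number from compound 2 to compound 3 (0.04 log units; within the scatter). The ethyl swap made four bonds along the chain gave a 1.0-fold higher number from compound 1 to compound 2 (0.00 log units; within the scatter). The larger swap, butyl in place of hydrogen four bonds along the chain, gave a 1.1-fold lower number from compound 1 to compound 3 (0.04 log units; within the scatter).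

None of these three steps moved the number beyond the scatter, so no real shift is expected in this assay from this further extension. Still, the measured compounds cannot show whether that holds for a chain longer than any tested so far.

The expected change is a 1.0-fold higher number from compound 3 to compound 4 (0.01 log units; within the scatter), which would be no step beyond the scatter. For compound 4 the estimated value is 40000000 nM, with an expected range from 22000000 nM to 70000000 nM.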

Compound 4, half-maximal inhibitory concentration: 35100000 nM
The estimate for compound 4 lay 1.1-fold (0.06 log units) above the measured number, and the stated range covers the measured number.
By their numbers in this assay, from the lowest: compounds 4, 3, 1 and 2 (each within the scatter of the next).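

In this assay, the ethyl swap now reaches eight bonds along the chain from the oxygen on the aromatic ring and still does not move the number beyond the scatter, with a 1.1-fold lower number from compound 3 to compound 4 (0.05 log units; within the scatter). The bigger jumps that compound 4 adds read the same way, with a 1.2-fold lower number from compound 2 to compound 4 (0.08 log units; within the scatter) and a 1.2-fold lower number from compound 1 to compound 4 (0.08 log units; within the scatter), so even hexyl in place of hydrogen four bonds along the chain, the largest chain change in this set, leaves the number level. The ethyl swap also gives matching results at two places along the chain, which the earlier compounds could not show, since they offered only one pair to compare with no second pair beside it: the same change on two cores in this assay, a 1.0-fold higher number (0.00 log units; within the scatter) from compound 1 to compound 2 and a 1.1-fold lower number (0.05 log units; within the scatter) from compound 3 to compound 4, 1.1-fold (0.05 log units) apart, within the scatter of two such steps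

On these data alone, all four compounds carry a plain saturated chain, so it remains open whether a longer chain than that of compound 4, or a chain ending in an amine or a carboxylic acid, would move the number beyond the scatter. The compounds also leave open whether replacing the bromine on the shared core with another group, such as chlorine or a nitrile, would shift the number in this assay.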